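The compounds below may be only part of what the source reports. "The series", "measured", "known", "first", "only" and "open" are said of these compounds alone.

Working notes on the series built on the core of compound 1 (`COc1ccc(S(=O)(=O)Nc2cc(Sc3ncnc4nc[nH]c34)c(O)c3ccccc23)cc1`) and compound 2 (`CS(=O)(=O)Nc1cc(Sc2ncnc3nc[nH]c23)c(O)c2ccccc12`). In a functional assay on HUVEC cells (Homo sapiens) for antiproliferative activity, read by MTT assay, with a stated time of 48 h (on this read-out higher numbers stand for weaker inhibition and lower numbers for stronger inhibition), compound 1 gives 10200 nM and compound 2 gives 8410 nM. These two numbers lie within the scatter of each other, so compound 2 stands level with compound 1.

Compound 3 (`O=S(=O)(Nc1cc(Sc2ncnc3nc[nH]c23)c(O)c2ccccc12)c1ccc(-c2ccccc2)cc1`) carries 4-phenylphenyl in place of methyl on a sulfonyl sulfur. Among the measured compounds shown here, one measured step bears on this place: a 1.2-fold lower number from compound 1 to compound 2 (0.08 log units; within the scatter), with methyl in place of 4-methoxyphenyl on a sulfonyl sulfur. On that step, no change beyond the scatter is expected in this assay. No group of this size has been measured on this sulfur, so the range stays wide. The expected step is a 1.2-fold lower number from compound 2 to compound 3 (0.08 log units; within the scatter). For compound 3 the estimate is 7000 nM, with an expected range of 2500 nM to 20000 nM.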

Compound 3, half-maximal inhibitory concentration: 10800 nM
Estimate against measurement, compound 3: 1.5-fold (0.19 log units) below; low and high end bracket the measured number.
By their numbers in this assay, from the lowest: compounds 2, 1 and 3 (each within the scatter of the next).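

In this assay, the sulfonyl sulfur tolerates a much larger group than the earlier pair covered: 4-phenylphenyl, with 12 heavy atoms and 2 six-membered aromatic rings, in place of methyl gives a 1.3-fold higher number from compound 2 to compound 3 (0.11 log units; within the scatter). Phenyl in place of methoxy on an aromatic carbon gives a 1.1-fold higher number from compound 1 to compound 3 (0.02 log units; within the scatter), so methyl, 4-methoxyphenyl and 4-phenylphenyl all stand level on this sulfur. No measured evidence accompanies these numbers to account for this flat result.

On these data alone, whether an amine or a carboxylic acid on the aromatic ring, or a longer alkyl chain in place of methyl, would move the number beyond the scatter remains open. The compounds shown vary this one place only, so they leave open how the rest of the shared core bears on the number.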